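A few compounds are considered here, and "the series" means these few. Any claim that something is new, unique, unknown or untested is made for them only; others in the source may bear on it.

In a functional assay on DU-145 cells (Homo sapiens) for cytotoxicity, read by MTT assay, with a stated time of 48 h (a higher number here means a weaker inhibitor, a lower number a stronger inhibitor), three compounds that share one core have been measured. Compound 1 `C=C1CCC[C@]2(C)CCC(C=O)=CC[C@@]12C` gives 152000 nM and compound 3 `C=C1CCC[C@]2(C)CCC(c3cn(-c4ccc(I)cc4)nn3)=CC[C@@]12C` gives 145000 nM. Compound 2 `C=C1CCC[C@]2(C)CCC(c3cn(-c4ccc(OC)cc4)nn3)=CC[C@@]12C` gives 58900 nM, the lowest number of the three, which makes it the strongest inhibitor so far, though all three values are high.

The next compound to be tested is compound 4 `C=C1CCC[C@]2(C)CCC(c3cn(-c4ccc(C)cc4)nn3)=CC[C@@]12C`. It differs from compound 2 in one place, with methyl in place of methoxy on an aromatic carbon.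

Going by the values given here, only one measured step bears on this change. Iodo in place of methoxy at that same place gave a 2.5-fold higher number from compound 2 to compound 3 (0.39 log units; beyond the scatter), a modest change. That single step involves a different incoming group, so it is only a loose guide. A smaller step in the same direction, towards a weaker inhibitor, is expected for methyl. The estimated change is a 1.4-fold higher number from compound 2 to compound 4 (0.16 log units; within the scatter). For compound 4, the estimated value in this assay is 85000 nM, with an expected range from 40000 nM to 170000 nM.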

Compound 4, half-maximal inhibitory concentration: 132000 nM
For compound 4 the middle estimate is 1.6-fold (0.19 log units) below the measured one; low and high end bracket the measured number.
By their numbers in this assay, from the lowest: compound 2; then compounds 4, 3 and 1 (each within the scatter of the next).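

In this assay, methyl in place of methoxy on the aromatic ring gives a clear step (a 2.2-fold higher number from compound 2 to compound 4 (0.35 log units; beyond the scatter)), so a second replacement for methoxy at this place now also moves the number upward. Methyl and iodo cannot be told apart (a 1.1-fold lower number from compound 3 to compound 4 (0.04 log units; within the scatter)), which leaves methoxy as the one group of these three that stands apart, with compound 2 the stronger inhibitor in both of its steps at this place. Nothing measured here gives a reason for this difference.

As far as these compounds go, whether the oxygen of methoxy is what matters stays open; a hydroxyl, an ethoxy group or a plain hydrogen at the same place would test that. Also open, from the compounds shown here alone, is whether any group here can lower the number much further, given that even compound 2 stands at 58900 nM.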